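Adding a Chloro to Compound 3

The compounds below may be only part of what the source reports. "The series", "measured", "known", "first", "only" and "open" are said of these compounds alone.

In a functional assay on U-87MG ATCC cells for antiproliferative activity against U-87 MG (Homo sapiens), read by MTT assay, with a stated time of 48 h (a lower number here means a stronger inhibitor, a higher number a weaker inhibitor), compound 3 (`Cc1nc(-c2ccccc2)sc1C(=O)CSc1nc(-c2ccc(Cl)cc2)c(C#N)c(=O)[nH]1`) gives 43400 nM. That value lies within the usual scatter of the two other measured compounds: compound 1 (`Cc1nc(-c2ccc(Cl)cc2)sc1C(=O)CSc1nc(-c2ccccc2)c(C#N)c(=O)[nH]1`) gives 27600 nM, and compound 2 (`Cc1nc(-c2ccc(Cl)cc2)sc1C(=O)CSc1nc(-c2ccc(Cl)c(Cl)c2)c(C#N)c(=O)[nH]1`) gives 83900 nM. Compound 4 (`Cc1nc(-c2ccc(Cl)cc2)sc1C(=O)CSc1nc(-c2ccc(Cl)cc2)c(C#N)c(=O)[nH]1`) has chloro in place of hydrogen on an aromatic carbon, para to a large group, so that phenyl becomes 4-chlorophenyl: chloro in place of hydrogen on an aromatic carbon. Among the measured compounds shown here, no measured step makes this exact change. The only one available, a 3.0-fold higher number from compound 1 to compound 2 (0.48 log units; beyond the scatter), puts 3,4-dichlorophenyl in place of phenyl at a different place in the molecule, and it was modest. That single step is thin support, and it adds more than the one chloro at issue here. Resting on it, no shift beyond the scatter is expected in this assay, with only a slight lean towards a higher number. The estimated change is a 1.2-fold higher number from compound 3 to compound 4 (0.06 log units; within the scatter). For compound 4 the estimated value is 50000 nM, with an expected range from 20000 nM to 120000 nM.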

Compound 4, half-maximal inhibitory concentration: 53000 nM
Beside the measured number, compound 4's estimate is 1.1-fold (0.03 log units) below it; the measured number falls inside the stated range.
By their numbers in this assay, from the lowest: compounds 1, 3, 4 and 2 (each within the scatter of the next, the first and the last beyond it).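

In this assay, the single chloro that turns the phenyl of compound 3 into 4-chlorophenyl can now be read directly, and the result, a 1.2-fold higher number from compound 3 to compound 4 (0.09 log units; within the scatter), stays within the scatter. The same holds for chloro in place of hydrogen on the other phenyl, a 1.9-fold higher number from compound 1 to compound 4 (0.28 log units; within the scatter), and for the loss of one chloro from the 3,4-dichlorophenyl group, a 1.6-fold lower number from compound 2 to compound 4 (0.20 log units; within the scatter), so only the full change from phenyl to 3,4-dichlorophenyl, a 3.0-fold higher number from compound 1 to compound 2 (0.48 log units; beyond the scatter), lies beyond the scatter. Nothing available accounts for these steps.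

Going by these compounds, these phenyl groups carry only hydrogen or chloro, so it remains open whether an amine, a methoxy group or a carboxylic acid in that place would move the number beyond the scatter. On these data alone, the nitrile and the methyl group are common to all four compounds, so what either contributes also remains open.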